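Removing the Methyl from Selenium: What Compound 4 May Show

The source may hold more compounds than are shown below. What is called first, only, known or untested is meant among the compounds shown, and "the series" means these compounds.

Measured compounds:
compound 1, `C[Se]c1nc(N)c2ccccc2n1`: 54600 nM
compound 2, `Sc1nc(NCc2ccccc2)c2ccccc2n1`: > 100000 nM
compound 3, `CCCCC[Se]c1nc(N)c2cccnc2n1`: 44900 nM

In an ADME assay on BEAS-2B cells (Homo sapiens) for cytotoxicity, read by MTT assay, with a stated time of 72 h (on this read-out higher numbers stand for weaker inhibition of growth and lower numbers for stronger inhibition of growth), compound 1 gives 54600 nM. Compound 3 gives 44900 nM in this assay, and the two numbers lie within the usual scatter of each other, so no order between them can be read. For compound 2 the assay reports only a limit, > 100000 nM, consistent with the limit of > 100000 nM in this assay, at which 1 of the 3 values shown sits. Compound 1 therefore holds the higher of the two plain numbers, with compound 3 close by.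

Compound 4, `Nc1nc([SeH])nc2ccccc12`, differs from compound 1 by hydrogen in place of methyl on a selenium. Within the data shown here, no measured pair shows this change, so its effect in this assay is unknown and the estimate rests on compound 1 alone. The step is expected to be none beyond the scatter, as expressed by a 1.1-fold lower number from compound 1 to compound 4 (0.04 log units; within the scatter). For compound 4 the expected value is 50000 nM, with a range from 20000 nM to 100000 nM.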

Compound 4, concentration for total growth inhibition: > 100000 nM
Compound 4: only a limit was reported; the forecaster's own chance of this, stated with the estimate: 30%; at least 2.0-fold (0.30 log units) between middle value and limit.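

In this assay compound 4 is reported only as a limit, > 100000 nM. Hydrogen in place of methyl on a selenium amounts to an at least 1.8-fold higher number from compound 1 to compound 4 (0.26 log units; that floor lies within the scatter), so this change has a floor and no full size, and that floor alone does not separate the two compounds. This gives the first direct reading at this position, and it ends at the edge of the read-out rather than at a plain number: the limit of > 100000 nM in this assay, at which 2 of the 4 values shown sit.

On these data alone, how far the true value of compound 4 lies from compound 1 therefore stays open, and so does whether the change has any real effect in this assay. Also open, as far as these compounds go, is how an ethyl group or a longer chain on the selenium of the core of compound 1 would read.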